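Swapping a benzyl for a bromophenyl thiourea on the core

The compounds below may be only part of what the source reports. "The series", "measured", "known", "first", "only" and "open" are said of these compounds alone.

Measured compounds:
- compound 1, `NC(=O)c1c(NC(=O)c2ccccc2Cl)sc2c1CCN(Cc1ccccc1)C2`: 14500 nM
- compound 2, `NC(=O)c1c(NC(=O)c2ccc(C(F)(F)F)cc2)sc2c1CCN(Cc1c(Cl)cccc1Cl)C2`: 8530 nM
- compound 3, `NC(=O)c1c(NC(=O)c2ccccc2F)sc2c1CCN(Cc1ccc(Cl)cc1Cl)C2`: 9610 nM

The three measured compounds share one core and are read in a functional assay on MKN-74 cells (Homo sapiens) for antiproliferative activity, with a stated time of 24 h; a higher number here means a weaker inhibitor, a lower number a stronger inhibitor. In this assay compound 1 gives 14500 nM, the highest of the three numbers. That number, however, lies within the usual scatter of both compound 3 and compound 2, so the three compounds cannot be ranked against each other on what has been measured; all three sit at weak inhibition.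

Compound 4, `NC(=O)c1c(NC(=O)c2ccccc2Cl)sc2c1CCN(C(=S)Nc1ccccc1Br)C2`, has not yet been measured. It differs from compound 1 in one place: a group of 10 heavy atoms (7 carbon, 1 nitrogen, 1 sulfur, 1 bromine; one six-membered aromatic ring of carbon only) in place of a group of 7 heavy atoms (7 carbon; one six-membered aromatic ring of carbon only), on an amine nitrogen in a ring. The part that leaves is the benzyl; the part that enters carries a double bond outside the aromatic ring, one hydrogen-bond donor and one hydrogen-bond acceptor, on the amine nitrogen in the ring.

Among the measured compounds shown here, no measured pair shows what this kind of exchange does here, so the expected step from compound 1 to compound 4 is estimated at a 1.6-fold lower number from compound 1 to compound 4 (0.21 log units; within the scatter), a small move toward a lower number that may still fall inside the scatter. Compound 4 is therefore expected to give about 9000 nM, in a range from 3000 nM to 30000 nM.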

Compound 4, half-maximal inhibitory concentration: 10800 nM
Compound 4: middle estimate off by 1.2-fold (0.08 log units), on the low side; the measured number falls inside the stated range.
By their numbers in this assay, from the lowest: compounds 2, 3, 4 and 1 (each within the scatter of the next).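

Among the compounds shown here, this is the first comparison that changes only one place, the group on the amine nitrogen in the ring, with the rest of compound 1 held constant. In this assay, replacing the benzyl with the bromophenyl thiourea, which brings a sulfur, a bromine, a hydrogen-bond donor and a hydrogen-bond acceptor, gives a 1.3-fold lower number from compound 1 to compound 4 (0.13 log units; within the scatter), so this sizeable change in the group produces no readable difference in antiproliferative activity, and compound 4 stays among the weak inhibitors. Nothing available explains why the two groups read alike.

One exchange cannot show whether this position is generally insensitive to what is placed there, or whether a urea, with oxygen in place of the thiourea sulfur, a simple acetyl or a chain ending in a dimethylamino group would move the number beyond the scatter. On these data alone, the effect of the aromatic groups on the amide and on the benzyl also stays open, since compound 2 and compound 3 each differ from compound 1 in more than one place.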